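Bromo Swapped for Methoxy on Compound 2

This account rests on a few compounds, and the source may have more. Where it says the series, first, only, none or still open, it means among the compounds named here.

In a functional assay on COLO 205 cells (Homo sapiens) for inhibition, read by sulforhodamine B assay, tested at 100 uM (on this read-out higher numbers stand for more inhibition of growth at the one concentration tested and lower numbers for less inhibition of growth), compound 2 `COc1cc(C2CC(c3ccc(Br)cc3)=NN2C(C)=O)ccc1OCc1cn(Cc2ccc([N+](=O)[O-])cc2)nn1` gives 47%. Compound 1 `COc1cc(C2CC(c3ccc(OCc4cn(Cc5ccc([N+](=O)[O-])cc5)nn4)cc3)=NN2C(C)=O)ccc1Oc1cn(Cc2ccc([N+](=O)[O-])cc2)nn1` gives 51% in this assay, so compound 2 holds the lower of the two numbers, yet compound 1 sits only slightly higher, within the scatter. Compound 3 `COc1ccc(C2=NN(C(C)=O)C(c3ccc(OCc4cn(Cc5ccc([N+](=O)[O-])cc5)nn4)c(OC)c3)C2)cc1` differs from compound 2 by methoxy in place of bromo on an aromatic carbon. Among the compounds with values here, no pair of measured compounds shows the effect of such a change, so the expected step, a number 2 percentage points lower from compound 2 to compound 3 (within the scatter), is estimated to stay within the scatter in this assay. Compound 3 is therefore expected to give about 45%, with a range from 25% to 65%.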

Compound 3, percent growth inhibition at one concentration: 75%
The estimate for compound 3 lay 30 percentage points below the measured number; measured number outside the range, above it.
By their numbers in this assay, from the lowest: compounds 2 and 1 (each within the scatter of the next); then compound 3.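

In this assay, within the data shown here, the change from 4-bromophenyl to 4-methoxyphenyl gives a number 28 percentage points higher from compound 2 to compound 3 (beyond the scatter), the first step between measured compounds that differ in one place. It shows that the group on this aromatic carbon, para to a large group, can move growth inhibition beyond the scatter. Nothing available accounts for the size of this step.

The compounds shown leave open how an amine, a carboxylic acid or a longer chain on this carbon would read, and so whether the step is particular to methoxy. They also leave open whether the same change would give a similar step on another core.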